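Cyclohexyl for phenyl on a carbamate nitrogen and cytotoxicity

A few compounds are considered here, and "the series" means these few. Any claim that something is new, unique, unknown or untested is made for them only; others in the source may bear on it.

The set is built around two cores. Compound 3 `O=C(Nc1ccccc1)Oc1ccccc1C(=O)Nc1ccccc1` and compound 1 `O=C(NC1CCCCC1)Oc1ccccc1C(=O)Nc1ccccc1` share one; compound 2 `O=C(Nc1ccccc1)Oc1ccc(Cl)cc1C(=O)Nc1ccc(Cl)cc1` and compound 4 `O=C(NC1CCCCC1)Oc1ccc(Cl)cc1C(=O)Nc1ccc(Cl)cc1` share the other, and the difference between the two cores is not broken down here. In an ADME assay on HepG2 cells (Homo sapiens) for cytotoxicity, read by MTT assay (on this read-out higher numbers stand for weaker inhibition and lower numbers for stronger inhibition), compound 3 gives 57700 nM. Compound 1 gives 49000 nM in this assay. Between them lies one change, (cyclohexyl in place of phenyl on an amide-type nitrogen), and its step was a 1.2-fold lower number from compound 3 to compound 1 (0.07 log units; within the scatter). Compound 2 reaches only a limit in this assay, > 250000 nM, which is a limit of the measurement and not a number; it sits at the limit of > 250000 nM in this assay, at which 1 of the 3 values shown sits. Compound 4 differs from compound 2 by the same change, (cyclohexyl in place of phenyl on an amide-type nitrogen). Since the step from compound 3 to compound 1 stayed within the scatter, the step from compound 2 to compound 4 is expected to be about a number no higher from compound 2 to compound 4 (the limit leaves the size open), and compound 4 will most likely again be reported only as a limit. The estimate for compound 4 in this assay is 250000 nM, in a range from 120000 nM to 500000 nM.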

Compound 4, half-maximal inhibitory concentration: > 250000 nM
Compound 4: only a limit was reported; the forecaster's own chance of this, stated with the estimate: 75%; the middle value lies on the limit itself.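

Compound 2 and compound 4 are each reported only as a limit of the measurement in this assay, so no step can be read between them: the limit of > 250000 nM in this assay, at which 2 of the 4 values shown sit. The compounds shown leave open how cyclohexyl in place of phenyl on an amide-type nitrogen acts on the core shared by compound 2 and compound 4, and how far either compound lies beyond the limit.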